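Swapping one six-membered ring for another at the ether oxygen

The source may report more compounds than this note shows. Statements on the series, on what has been measured and on what is new or still open speak of the compounds shown alone.

Compound 1 `CC(C)(C)OC(=O)N1CCC(O[C@H]2CC[C@H](Oc3ccc(S(C)(=O)=O)cc3)CC2)CC1`: 16.1 nM
Compound 2 `CC(C)(C)OC(=O)N1CCC(O[C@H]2CC[C@H](Oc3ccc(S(C)(=O)=O)cn3)CC2)CC1`: 47 nM
Compound 3 `CC(C)(C)OC(=O)N1CCC(O[C@H]2CC[C@H](Oc3cnc(S(C)(=O)=O)cn3)CC2)CC1`: 5.9 nM

In a functional assay on isolated protein for agonist activity at Glucose-dependent insulinotropic receptor (Homo sapiens), read by HTRF and cAMP accumulation (a higher number here means that more compound is needed for the effect, a lower number that less compound is needed), compound 3 gives the lowest of the three numbers. Compound 4 `CC(C)(C)OC(=O)N1CCC(O[C@H]2CC[C@H](Oc3ccc(S(C)(=O)=O)nn3)CC2)CC1` differs from it by one change: 6-(methylsulfonyl)pyridazin-3-yl in place of 5-(methylsulfonyl)pyrazin-2-yl on an oxygen on a saturated carbon. Among the compounds with values here, no measured step makes exactly this exchange, so only neighbours help. Replacing the ring in compound 1 gave a 2.9-fold higher number from compound 1 to compound 2 (0.47 log units; beyond the scatter) and a 2.7-fold lower number from compound 1 to compound 3 (0.44 log units; beyond the scatter); the two ring exchanges pulled in opposite directions, and an 8.0-fold lower number from compound 2 to compound 3 (0.90 log units; beyond the scatter) shows how far apart they landed. A ring exchange of this kind is therefore expected to move this assay modestly, but its direction is uncertain. Compound 4 is estimated at 15 nM, between 4 nM and 60 nM, meaning a 2.5-fold higher number from compound 3 to compound 4 (0.41 log units; beyond the scatter) is expected.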

Compound 4, half-maximal effective concentration: 651 nM
The estimate for compound 4 lay 43-fold (1.64 log units) below the measured number; the measured number lies above the stated range.
By their numbers in this assay, from the lowest: compound 3; then compound 1; then compound 2; then compound 4.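

Rearranging the ring atoms, with the same atoms present overall, gives a 110-fold higher number from compound 3 to compound 4 (2.04 log units; beyond the scatter) in this assay, so this position responds far more strongly to the ring's atom arrangement than the earlier ring exchanges showed. The 6-(methylsulfonyl)pyridazin-3-yl ring also stands apart from the other two rings, with a 14-fold higher number from compound 2 to compound 4 (1.14 log units; beyond the scatter) and a 40-fold higher number from compound 1 to compound 4 (1.61 log units; beyond the scatter) as its remaining steps. Nothing available here explains this jump. Still open, from the compounds shown here alone, is whether the jump depends on the methylsulfonyl group, which could be tested by putting a nitrile or a carboxylic acid in its place on these rings.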